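The source may hold more compounds than are shown below. What is called first, only, known or untested is meant among the compounds shown, and "the series" means these compounds.

Measured so far:
compound 1 `CCn1cc(C(=O)O)c(=O)c2cc(F)c(N3CCN(CN4C(=O)/C(=N\c5ncc(Cc6cc(OC)c(OC)c(OC)c6)c(N)n5)c5cc(Cl)ccc54)C(C)C3)c(F)c21`: 36.9 ug/mL in an ADME assay on MT4 cells (Homo sapiens) for cytotoxicity, read by MTT assay, with a stated time of 5 days; a higher number here means that more compound is tolerated, a lower number that less compound is tolerated
compound 2 `COc1cc(Cc2cnc(/N=C3\C(=O)N(CN4CCC(C)CC4)c4ccc(Cl)cc43)nc2N)cc(OC)c1OC`: 67.4 ug/mL in this assay
compound 3 `COc1cc(Cc2cnc(/N=C3\C(=O)N(CN4CCN(c5c(F)cc6c(=O)c(C(=O)O)cn(C7CC7)c6c5F)CC4C)c4ccc(Cl)cc43)nc2N)cc(OC)c1OC`: "not determined" (no result reported) in this assay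

Compound 2 holds the highest of the two numbers in this assay, but its gap to compound 1 lies within the usual scatter, so no order between the two is claimed. Compound 3 contributes nothing here.

Compound 4 `COc1cc(Cc2cnc(/N=C3\C(=O)N(CN4CCN(c5ccccn5)CC4)c4ccc(Cl)cc43)nc2N)cc(OC)c1OC` differs from compound 2 by 4-(pyridin-2-yl)piperazin-1-yl in place of 4-methylpiperidin-1-yl on a saturated chain carbon bound to an amide-type nitrogen in a ring. Going by the values given here, no step between measured compounds involves this change, so there is no direct precedent. The expected step from compound 2 to compound 4 in this assay is none beyond the scatter, a 1.3-fold lower number from compound 2 to compound 4 (0.13 log units; within the scatter), with a slight lean toward less compound tolerated. For compound 4 the estimate in this assay is 50 ug/mL, with a range from 20 ug/mL to 120 ug/mL.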

Compound 4, half-maximal cytotoxic concentration: 39.2 ug/mL
Compound 4: the middle estimate sits 1.3-fold (0.11 log units) above what was measured, within the range that was stated.
By their numbers in this assay, from the lowest: compounds 1, 4 and 2 (each within the scatter of the next).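

With 4-(pyridin-2-yl)piperazin-1-yl in place of 4-methylpiperidin-1-yl on a saturated chain carbon bound to an amide-type nitrogen in a ring, this assay gives a 1.7-fold lower number from compound 2 to compound 4 (0.24 log units; within the scatter) as the first step read at this position. The entering group adds a second ring and more nitrogen, yet the step stays within the scatter. No measurement on these groups is available to explain this result. Open, going by these compounds, is whether morpholin-4-yl at this position would move the number beyond the scatter. Also open, on these data alone, is whether 4-phenylpiperazin-1-yl would read like compound 4.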